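Ester in place of amide on the acrylate chain: compound 4

The source may report more compounds than this note shows. Statements on the series, on what has been measured and on what is new or still open speak of the compounds shown alone.

Measured in a functional assay on HCT-116 cells (Homo sapiens) for inhibition, read by MTT assay, with a stated time of 72 h; on this read-out higher numbers stand for weaker inhibition of growth and lower numbers for stronger inhibition of growth:
Compound 1 `COC1CN(C(=O)/C=C/c2ccncc2-c2ccc3ccccc3c2)C1` gives > 30000 nM, which is a limit of the assay.
Compound 2 `COC(=O)/C=C/c1ccncc1-c1ccc2ccccc2c1` gives 350 nM.
Compound 3 `O=C(/C=C/c1ccncc1-c1ccc2ccccc2c1)N1CCOCC1` gives 6040 nM.

Compound 3 stands highest of the two numbers shown; the nearest step to it is a 17-fold higher number from compound 2 to compound 3 (1.24 log units; beyond the scatter). Compound 4 `CCOC(=O)/C=C/c1ccncc1-c1ccc2ccccc2c1` differs from compound 3 by ethoxy in place of morpholin-4-yl on a carbonyl carbon. The step that bears on this is a 17-fold higher number from compound 2 to compound 3 (1.24 log units; beyond the scatter), the same exchange run the other way with methoxy rather than ethoxy, and it was large; an at least 4.9-fold lower number from compound 1 to compound 3 (0.69 log units; beyond the scatter), also leaving an amide for a smaller group, points the same way. A large drop in this assay is therefore expected, estimated as a 15-fold lower number from compound 3 to compound 4 (1.18 log units; beyond the scatter). Compound 4 is estimated at 400 nM, within 150 nM to 1200 nM.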

Compound 4, concentration for 50% growth inhibition: 910 nM
Compound 4: the middle estimate sits 2.3-fold (0.36 log units) below what was measured, within the range that was stated.
By their numbers in this assay, from the lowest: compound 2; then compound 4; then compound 3. At a limit, above all of these: compound 1.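

In this assay, the gain from leaving the morpholin-4-yl amide for an ester holds with ethoxy as it did with methoxy: a 6.6-fold lower number from compound 3 to compound 4 (0.82 log units; beyond the scatter). This position also responds to the ester group itself, not only to ester against amide, since adding one methyl on the saturated chain carbon gives a 2.6-fold higher number from compound 2 to compound 4 (0.41 log units; beyond the scatter). With compound 1 held at a limit, an at least 32-fold lower number from compound 1 to compound 4 (1.51 log units; beyond the scatter) is a bound and no more: the limit of > 30000 nM in this assay, at which 1 of the 4 values shown sits.

As far as these compounds go, whether a longer chain, such as a propyl or butyl ester, extends the loss from methoxy to ethoxy remains open. So does how the free carboxylic acid or a simple secondary amide on this carbonyl carbon would compare.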